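Para-substituent variation on the aryl group of the shared core

The source may report more compounds than this note shows. Statements on the series, on what has been measured and on what is new or still open speak of the compounds shown alone.

Going by the values given here, compound 3 `Fc1ccc(C2=NN(C3=NC(c4ccccc4)CS3)C(c3ccc4ccccc4c3)C2)cc1` stands highest of the three numbers so far in a functional assay on BGC-823 cells (Homo sapiens) for inhibition, read by CCK-8 assay, with a stated time of 48 h (on this read-out lower numbers stand for stronger inhibition and higher numbers for weaker inhibition), where compound 3 gives 17300 nM. Its nearest neighbour is compound 1 `Brc1ccc(C2=NN(C3=NC(c4ccccc4)CS3)C(c3ccc4ccccc4c3)C2)cc1`, which in this assay gives 13000 nM; the step of a 1.3-fold higher number from compound 1 to compound 3 (0.12 log units; within the scatter) is within the scatter. Among the compounds with values here, compound 2 `Cc1ccc(C2=NN(C3=NC(c4ccccc4)CS3)C(c3ccc4ccccc4c3)C2)cc1C` gives 6570 nM in this assay, and the step of a 2.6-fold higher number from compound 2 to compound 3 (0.42 log units; beyond the scatter) is the only one among the measured pairs that lies beyond the scatter; the step of a 2.0-fold lower number from compound 1 to compound 2 (0.30 log units; within the scatter) does not.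

Compound 4 `c1ccc(C2=NN(C3=NC(c4ccccc4)CS3)C(c3ccc4ccccc4c3)C2)cc1` differs from compound 3 by hydrogen in place of fluoro on an aromatic carbon.

The step that bears most directly on this change is the swap of one halogen for another at the same aromatic carbon, a 1.3-fold higher number from compound 1 to compound 3 (0.12 log units; within the scatter), which stayed within the scatter. The larger move to the dimethyl pattern, a 2.6-fold higher number from compound 2 to compound 3 (0.42 log units; beyond the scatter), was modest. Removing the halogen altogether is a change of similar extent, so no step beyond the scatter is expected in either direction for this assay.

Compound 4 is therefore estimated at 15000 nM in this assay, with a range from 7000 nM to 32000 nM, which corresponds to an expected step of a 1.2-fold lower number from compound 3 to compound 4 (0.06 log units; within the scatter).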

Compound 4, half-maximal inhibitory concentration: 9620 nM
Estimate against measurement, compound 4: 1.6-fold (0.19 log units) above; low and high end bracket the measured number.
By their numbers in this assay, from the lowest: compounds 2, 4, 1 and 3 (each within the scatter of the next, the first and the last beyond it).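

Working notes on this position. In this assay, taking the fluoro off this aromatic carbon leaves the number within the scatter (a 1.8-fold lower number from compound 3 to compound 4 (0.25 log units; within the scatter)), and replacing bromo with hydrogen at the same carbon does the same (a 1.4-fold lower number from compound 1 to compound 4 (0.13 log units; within the scatter)), so neither halogen is set apart from hydrogen here. The phenyl compound also stays within the scatter of the 3,4-dimethylphenyl compound (a 1.5-fold higher number from compound 2 to compound 4 (0.17 log units; within the scatter)), which places compound 4 within the scatter of all three earlier compounds and leaves the gap between compound 2 and compound 3 as the only one beyond it, with the unsubstituted ring giving no separate level of inhibition. Nothing at hand offers an explanation for this flat picture.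

Still open, on these data alone, is whether a group of a different kind on this ring, such as an amine, a carboxylic acid, a methoxy or a longer alkyl chain, would shift the number beyond the scatter. The compounds shown also leave open how far the number depends on the other aryl groups of the shared core, since those stay the same throughout.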